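A few compounds are considered here, and "the series" means these few. Any claim that something is new, unique, unknown or untested is made for them only; others in the source may bear on it.

Measured compounds:
- Compound 1 `COc1cncc(C(=O)Nc2cnn(Cc3c(C)noc3C)c2)c1` gives 800 nM in a functional assay on cells for antagonist activity at taste receptor type 2 member 8 (Homo sapiens), read by FLIPR and calcium flux, with a stated time of 100 s; on this read-out higher numbers stand for weaker inhibition and lower numbers for stronger inhibition.
- Compound 2 `COc1cccc(C(=O)Nc2cnn(Cc3c(C)noc3C)c2)n1` gives 700 nM in this assay.
- Compound 3 `COc1ccccc1C(=O)Nc1cnn(Cc2c(C)noc2C)c1` gives 1900 nM in this assay.

Compound 1 stands second highest of the three numbers: it sits close to compound 2, with a 1.1-fold lower number from compound 1 to compound 2 (0.06 log units; within the scatter), and the step of a 2.4-fold higher number from compound 1 to compound 3 (0.38 log units; beyond the scatter) is the larger one. Compound 4 `COc1ccc(C(=O)Nc2cnn(Cc3c(C)noc3C)c2)cc1` has not yet been measured. It differs from compound 1 in one place: 4-methoxyphenyl in place of 5-methoxypyridin-3-yl on a carbonyl carbon, the six-membered aromatic ring with one hetero atom giving way to a ring of carbon only. Among the measured compounds shown here, two measured steps bear on this kind of exchange, each swapping a methoxypyridinyl ring for a methoxyphenyl ring on the carbonyl carbon: a 2.4-fold higher number from compound 1 to compound 3 (0.38 log units; beyond the scatter) and a 2.7-fold higher number from compound 2 to compound 3 (0.43 log units; beyond the scatter), both modest and beyond the scatter, both toward weaker inhibition. The methoxy group in compound 4 sits elsewhere on the ring than in compound 3, so the match is loose, but the direction is the best guide at hand. A modest step toward a higher number is therefore expected, a 1.9-fold higher number from compound 1 to compound 4 (0.27 log units; within the scatter). Compound 4 is estimated at 1500 nM, with a range from 600 nM to 4000 nM.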

Compound 4, half-maximal inhibitory concentration: 700 nM
Compound 4: the middle estimate sits 2.1-fold (0.33 log units) above what was measured; the range from low to high includes it.
By their numbers in this assay, from the lowest: compounds 2, 4 and 1 (each within the scatter of the next); then compound 3.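

In this assay, exchanging a methoxypyridinyl ring for a methoxyphenyl ring did not by itself weaken inhibition: 4-methoxyphenyl gave a 1.1-fold lower number from compound 1 to compound 4 (0.06 log units; within the scatter) and no change at the digits printed from compound 2 to compound 4 (within the scatter), so the weaker value of compound 3 does not extend to compound 4. The exchange of 2-methoxyphenyl for 4-methoxyphenyl gave a 2.7-fold lower number from compound 3 to compound 4 (0.43 log units; beyond the scatter), which shows that the two methoxyphenyl groups are not equivalent here and that the step to compound 3 cannot be read as a general effect of losing the ring nitrogen. Nothing available explains this difference.

The compounds shown leave open how an ethoxy group, an amine or a carboxylic acid would compare with methoxy on this ring. As far as these compounds go, all four also share the same core, so whether these steps carry over to another core remains unknown.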